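The compounds below may be only part of what the source reports. "The series", "measured", "known", "first", "only" and "open" are said of these compounds alone.

Compound 1 `Cc1cccc(CNc2ncnc3c2ncn3[C@@H]2O[C@H](CO)[C@@H](O)[C@H]2O)c1` carries a 3-methylphenyl group on a saturated chain carbon bound to a nitrogen on an aromatic ring. In a functional assay on K562 cells (Homo sapiens) for antiproliferative activity, with a stated time of 72 h (on this read-out higher numbers stand for weaker inhibition and lower numbers for stronger inhibition), compound 1 reaches only the limit of the assay, > 166000 nM. Compound 2 `COc1ccccc1CNc1ncnc2c1ncn2[C@@H]1O[C@H](CO)[C@@H](O)[C@H]1O` gives 89000 nM in this assay, so that an at least 1.8-fold lower number from compound 1 to compound 2 (0.27 log units; that floor lies within the scatter). Compound 3 `OC[C@H]1O[C@@H](n2cnc3c(NCc4cc(F)cc(F)c4)ncnc32)C(O)C1O` likewise sits at the limit in this assay, > 166000 nM. Compound 4 `OC[C@H]1O[C@@H](n2cnc3c(NCc4c(F)ccc(F)c4F)ncnc32)[C@H](O)[C@@H]1O` differs from compound 1 in that (2,3,6-trifluorophenyl in place of 3-methylphenyl on a saturated chain carbon bound to a nitrogen on an aromatic ring). For the measured compounds named here, no measured step covers this change directly, and the limit of > 166000 nM in this assay, at which 2 of the 3 values shown sit, shows how often the read-out stops at the limit for this series. Compound 4 is therefore expected to stay near that limit, with an estimated 150000 nM (range 60000 nM to 400000 nM), which would mean an at least 1.1-fold lower number from compound 1 to compound 4 (0.04 log units; that floor lies within the scatter).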

Compound 4, half-maximal inhibitory concentration: > 166000 nM
Compound 4: only a limit was reported (the forecaster's own chance of this, stated with the estimate: 65%); middle value at least 1.1-fold (0.04 log units) from the limit.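

Compound 4 and compound 1 both stand at a limit, so the step from one to the other cannot be read. Set against the 2-methoxyphenyl group, the 2,3,6-trifluorophenyl group gives an at least 1.8-fold higher number from compound 2 to compound 4 (0.27 log units; that floor lies within the scatter), so no difference beyond the scatter is shown at this position. Adding compound 4 makes the limit the usual outcome in the series: the limit of > 166000 nM in this assay, at which 3 of the 4 values shown sit.

As far as these compounds go, it remains open whether any group at this position can give a number clearly away from the limit in this assay. An amine or a carboxylic acid in place of the substituted phenyl ring would be one untested test of this among the compounds shown.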